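Chloro for Bromo on the Aryl Ketone Acid

A few compounds are considered here, and "the series" means these few. Any claim that something is new, unique, unknown or untested is made for them only; others in the source may bear on it.

Going by the values given here, compound 3 `O=C(O)/C=C/C(=O)c1ccc(Br)cc1` gives 27100 nM in a functional assay on LS174T cells (Homo sapiens) for inhibition, read by MTT assay, with a stated time of 72 h (a lower number here means a stronger inhibitor, a higher number a weaker inhibitor), the highest of the three numbers measured so far. Its nearest neighbour is compound 2 `CCc1ccc(C(=O)/C=C/C(=O)O)cc1`, which gives 21000 nM in this assay; the step of a 1.3-fold higher number from compound 2 to compound 3 (0.11 log units; within the scatter) lies within the scatter, so the two cannot be ranked against each other. Compound 1 `CC(C)(C)c1ccc(C(=O)/C=C/C(=O)O)cc1` gives 8740 nM in this assay, and the step of a 3.1-fold higher number from compound 1 to compound 3 (0.49 log units; beyond the scatter) is beyond the scatter, as is a 2.4-fold higher number from compound 1 to compound 2 (0.38 log units; beyond the scatter).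

Compound 4 `O=C(O)/C=C/C(=O)c1ccc(Cl)cc1` differs from compound 3 in one place: chloro in place of bromo on an aromatic carbon. Among the compounds with values here, none of the measured steps exchanges one halogen for another, so the closest guides are the two steps that brought in bromo. The step of a 1.3-fold higher number from compound 2 to compound 3 (0.11 log units; within the scatter) stayed within the scatter, while the step of a 3.1-fold higher number from compound 1 to compound 3 (0.49 log units; beyond the scatter) was modest. Within the data shown here, nothing among the measured compounds points to an exchange of bromo for chloro moving the number beyond the scatter, and the direction cannot be read from the data. The expected step is therefore a 1.1-fold higher number from compound 3 to compound 4 (0.04 log units; within the scatter), within the scatter. In this assay compound 4 is estimated at 30000 nM, with a range from 12000 nM to 75000 nM.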

Compound 4, half-maximal inhibitory concentration: 28700 nM
The estimate for compound 4 lay 1.0-fold (0.02 log units) above the measured number, and the stated range covers the measured number.
By their numbers in this assay, from the lowest: compound 1; then compounds 2, 3 and 4 (each within the scatter of the next).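

Among these compounds, this is the only exchange of one halogen for another, and in this assay it gives a 1.1-fold higher number from compound 3 to compound 4 (0.02 log units; within the scatter) at this aromatic carbon, so chloro and bromo cannot be told apart here. Chloro also cannot be separated from ethyl at the same position, with a 1.4-fold higher number from compound 2 to compound 4 (0.14 log units; within the scatter) on the printed numbers, which places ethyl, bromo and chloro together, each within the scatter of the others. Tert-butyl alone stands apart, since the new halogen compound repeats what bromo showed, with a 3.3-fold higher number from compound 1 to compound 4 (0.52 log units; beyond the scatter) as a modest change, and compound 1 is now the strongest inhibitor of the four, its steps to all three others lying beyond the scatter.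

The compounds shown leave open whether an amine, a methoxy group, fluoro or a longer chain at this position would stay with compounds 2, 3 and 4 or move towards compound 1, and whether an ester or amide in place of the carboxylic acid would alter the picture. No supporting measurement is available that bears on this result or could explain the separation of tert-butyl from the other groups.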